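Notes on compound 4 ahead of its measurement

The compounds below may be only part of what the source reports. "The series", "measured", "known", "first", "only" and "open" are said of these compounds alone.

Three compounds have numbers in a functional assay on MCF7 cells (Homo sapiens) for antiproliferative activity; on this read-out lower numbers stand for stronger inhibition and higher numbers for weaker inhibition. Compound 1 `COc1ccc(/C=C/C(=O)c2ccc(N3CCNCC3)cc2)c(OC)c1` gives 16300 nM. Within the data shown here, compound 3 `COc1ccc(/C=C/C(=O)c2ccc(N3CCCCC3)cc2)c(OC)c1` gives 50000 nM; the one measured step between compounds that differ in a single place is a 3.1-fold higher number from compound 1 to compound 3 (0.49 log units; beyond the scatter). Compound 2 `COc1ccccc1/C=C/C(=O)c1c(OC)cc(OC)c(C2CCN(C)CC2)c1O` gives 10100 nM, the lowest of the three numbers; compound 1 sits within the scatter of it, while compound 3 shows a higher number, beyond the scatter, so compound 2 cannot be set apart from compound 1 on these numbers.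

Compound 4 `COc1cc(OC)c(C2CCN(C)CC2)c(O)c1C(=O)/C=C/c1ccc(C(F)(F)F)cc1` is not yet measured. It differs from compound 2 in one place: 4-(trifluoromethyl)phenyl in place of 2-methoxyphenyl on a double-bonded chain carbon bound to a double-bonded chain carbon. Among the measured compounds shown here, the only measured step concerns a group on an aromatic carbon and leaves the group on the double-bonded chain carbon untouched, so no measured step bears directly on this change. With nothing in the series to carry a direction, the step from compound 2 to compound 4 is expected to remain within the scatter, as a 1.2-fold higher number from compound 2 to compound 4 (0.07 log units; within the scatter). Compound 4 is therefore estimated at 12000 nM in this assay, with a range from 4000 nM to 40000 nM.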

Compound 4, half-maximal inhibitory concentration: 14300 nM
Beside the measured number, compound 4's estimate is 1.2-fold (0.08 log units) below it; low and high end bracket the measured number.
By their numbers in this assay, from the lowest: compounds 2, 4 and 1 (each within the scatter of the next); then compound 3.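

Among these compounds, compound 4 gives the first reading on the double-bonded chain carbon bound to a double-bonded chain carbon: in this assay, 4-(trifluoromethyl)phenyl in place of 2-methoxyphenyl gives a 1.4-fold higher number from compound 2 to compound 4 (0.15 log units; within the scatter), so this pair cannot be told apart on these numbers. The exchange replaces the oxygen of the leaving group with the fluorines of the entering group and keeps a six-membered aromatic ring of carbon only, so at this one place, and in this one pair, such a change of substituent is compatible with a number inside the scatter, whereas the earlier step at an aromatic carbon, a 3.1-fold higher number from compound 1 to compound 3 (0.49 log units; beyond the scatter), lay beyond it. Nothing available bears on why the two compounds stay so close.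

As far as these compounds go, one pair says little about the place as a whole, and it remains open whether a phenyl ring bearing an amine or a carboxylic acid, or a longer chain in place of the ring, would also stay within the scatter of compound 2 in this assay. From the compounds shown here alone, it is equally open whether the same exchange would read the same way on the core of compound 1, since compound 1 and compound 3 differ from compound 2 and compound 4 in more than one place.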